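The source may hold more compounds than are shown below. What is called first, only, known or untested is meant among the compounds shown, and "the series" means these compounds.

Compound 1 `CC(Oc1ccc(Cl)cc1Cl)C(=O)NC(C)c1ccc(F)cc1`: > 100000 nM (a limit)
Compound 2 `CC(Oc1ccc(Cl)cc1Cl)C(=O)NC(c1ccc(F)cc1)C(C)C`: > 100000 nM (a limit)

In an ADME assay on CHO cells (Cricetulus griseus) for cytotoxicity, read by LDH release (a lower number here means a stronger inhibitor, a higher number a weaker inhibitor), compound 2 gives > 100000 nM as its reading, and this is a limit, not a number. Compound 1 also gives only a limit, so both compounds share one position (the limit of > 100000 nM in this assay, at which 2 of the 2 values shown sit) and compound 2 has no numeric value to be ranked.

Compound 3 `CC(Oc1ccc(Cl)cc1Cl)C(=O)NC(CO)c1ccc(F)cc1` carries hydroxymethyl in place of isopropyl on a saturated chain carbon bound to an amide-type nitrogen and an aromatic carbon. Among the compounds with values here, the one measured step at this place, a step that the two limits leave unreadable from compound 1 to compound 2, put isopropyl in place of methyl and has no readable size to carry over. No direction can be drawn from it for this assay, so no change beyond the scatter is expected, and a reading that again stops at the limit is the likeliest outcome. The expected step is a number no higher from compound 2 to compound 3 (the limit leaves the size open) and rests on that reasoning alone. For compound 3 the estimated value is 100000 nM, with an expected range of 40000 nM to 200000 nM.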

Compound 3, half-maximal inhibitory concentration: 18000 nM
Compound 3: middle estimate off by 5.6-fold (0.74 log units), on the high side, outside the stated range (below it).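

Within the data shown here, on the saturated chain carbon bound to an amide-type nitrogen and an aromatic carbon, this assay now responds to a change: hydroxymethyl in place of isopropyl gives an at least 5.5-fold lower number from compound 2 to compound 3 (0.74 log units; beyond the scatter), and compound 3, at 18000 nM, holds the only numeric reading at this place. Hydroxy in place of hydrogen on a saturated chain carbon, two bonds along the chain from an amide-type nitrogen and an aromatic carbon, gives an at least 5.5-fold lower number from compound 1 to compound 3 (0.74 log units; beyond the scatter), so the lower number appears against both the methyl and the isopropyl compound. Compound 1 and compound 2 each give only a limit, and the step between them cannot be read: the limit of > 100000 nM in this assay, at which 2 of the 3 values shown sit.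

An aminomethyl, a methoxymethyl or a carboxylic acid at this place would test whether the lower number goes with the hydroxy group itself or extends to other groups. On these data alone, the full size of both steps stays open, and so does whether a hydroxyethyl chain at this place keeps the lower number.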